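Methoxy to Isopropoxy: Expected Effect on Liver Clearance

A few compounds are considered here, and "the series" means these few. Any claim that something is new, unique, unknown or untested is made for them only; others in the source may bear on it.

Three compounds have been measured in an ADME assay on microsomes from liver (Mus musculus) for metabolic stability; on this read-out lower numbers stand for slow clearance and higher numbers for fast clearance:

Compound 1 `CCOc1cc([C@](O)(CCN(C)C)[C@@H](c2cc3cc(Br)ccc3nc2OC)c2ccnc(OC)c2OC)cc(OC)n1` gives 7.6 uL/min.
Compound 2 `CCCOc1cc([C@](O)(CCN(C)C)[C@@H](c2cc3cc(Br)ccc3nc2OC)c2ccnc(OC)c2OC)cc(OC)n1` gives 6.5 uL/min.
Compound 3 `COc1cc([C@](O)(CCN(C)C)[C@@H](c2cc3cc(Br)ccc3nc2OC)c2ccnc(OC)c2OC)cc(OC(F)F)n1` gives 4.9 uL/min.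

Compound 1 sits at one end of these three numbers, but a 1.2-fold lower number from compound 1 to compound 2 (0.07 log units; within the scatter) and a 1.6-fold lower number from compound 1 to compound 3 (0.19 log units; within the scatter) are both within the scatter, as is a 1.3-fold lower number from compound 2 to compound 3 (0.12 log units; within the scatter), so the three compounds cannot be told apart on this read-out.

Compound 4 `CCOc1cc([C@](O)(CCN(C)C)[C@@H](c2cc3cc(Br)ccc3nc2OC)c2ccnc(OC)c2OC)cc(OC(C)C)n1` is the unmeasured compound. It differs from compound 1 by isopropyl in place of methyl on an oxygen on an aromatic ring. The most comparable measured step is a 1.2-fold lower number from compound 1 to compound 2 (0.07 log units; within the scatter), in which a chain on an oxygen on an aromatic ring was lengthened by one carbon and the number barely moved. The two steps to compound 3 also change the group on an oxygen on an aromatic ring, and neither moved the number beyond the scatter. On that basis a step of a 1.2-fold lower number from compound 1 to compound 4 (0.07 log units; within the scatter) is expected, meaning no change beyond the scatter, with perhaps a slight drift toward a lower number.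

Compound 4 is therefore estimated at 6.5 uL/min, with a likely range from 3.5 uL/min to 12 uL/min.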

Compound 4, intrinsic clearance in a liver preparation (reported as CLH), per the amount of preparation that the assay uses: 1.6 uL/min
The estimate for compound 4 lay 4.1-fold (0.61 log units) above the measured number; the measured number lies below the stated range.
By their numbers in this assay, from the lowest: compound 4; then compounds 3, 2 and 1 (each within the scatter of the next).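

In this assay, for the compounds shown here, replacing methoxy with isopropoxy brings a 4.8-fold lower number from compound 1 to compound 4 (0.68 log units; beyond the scatter) and is the first step here to pass beyond the scatter, so the group on this oxygen can shift the read-out by a clear margin. Going by these compounds alone, the earlier steps, a 1.2-fold lower number from compound 1 to compound 2 (0.07 log units; within the scatter) and a 1.6-fold lower number from compound 1 to compound 3 (0.19 log units; within the scatter), both changed the ethyl group while the methyl stayed in place, and neither left the scatter; in this new step the ethyl stays and the methyl is what changes, and isopropyl is the only branched group in the set. No measurement shown here explains why this change lowers the number.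

With a single step at this place, the compounds shown cannot separate the effect of the branching from that of the added carbons, or show whether the same swap would matter on the ethyl side. A cyclopropyl or a tert-butyl group on this oxygen would test how far the trend holds, and an amine or a carboxylic acid on the isopropyl chain remains an open question for the same read-out.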